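Replacing the dichlorophenyl of compound 1 with a dimethoxyphenyl

The source may report more compounds than this note shows. Statements on the series, on what has been measured and on what is new or still open speak of the compounds shown alone.

The series rests on the shared core of compound 1 `COc1cc(-c2cc(/C=C/C(=O)c3ccc(Cl)c(Cl)c3)[nH]n2)cc(OC)c1OC`. In a functional assay on K562 cells (Homo sapiens) for cytotoxicity, read by sulforhodamine B assay, with a stated time of 48 h, tested at 0.1 uM (a lower number here means a stronger effect, a higher number a weaker effect of the compound at the concentration tested), compound 1 gives 106%, the highest of the three numbers. Compound 2 `COc1ccc(-c2cc(/C=C/C(=O)c3ccc(N)cc3)[nH]n2)cc1OC` gives 98% in this assay, a number within the scatter of compound 1, while compound 3 `COc1ccc(-c2cc(/C=C/C(=O)c3ccc(N)cc3)[nH]n2)cc1` gives 95% in this assay, which lies beyond the scatter of compound 1. Within the data shown here, the one step between measured compounds, a number 3 percentage points lower from compound 2 to compound 3 (within the scatter), involves hydrogen in place of methoxy on an aromatic carbon and is within the scatter, so it carries little information about any change in this assay.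

Compound 4 `COc1ccc(C(=O)/C=C/c2cc(-c3cc(OC)c(OC)c(OC)c3)n[nH]2)cc1OC` differs from compound 1 in one place: 3,4-dimethoxyphenyl in place of 3,4-dichlorophenyl on a carbonyl carbon. Among the measured compounds shown here, no measured step concerns the group on the carbonyl carbon, so nothing in the numbers bears directly on this change. For the measured compounds named here, all three measured numbers in this assay sit close to each other, and the one measured step is within the scatter. The expectation for compound 4 is therefore no step beyond the scatter, with a number 6 percentage points lower from compound 1 to compound 4 (within the scatter) as the estimated change. Compound 4 is estimated to give 100% in this assay, within a range from 87% to 112%.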

Compound 4, a percentage reported as activity, at one concentration (the size of the read-out at that concentration, not a potency): 92%
For compound 4 the middle estimate is 8 percentage points above the measured one; measured number inside the range.
By their numbers in this assay, from the lowest: compounds 4, 3, 2 and 1 (each within the scatter of the next, the first and the last beyond it).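

In this assay the exchange of 3,4-dichlorophenyl for 3,4-dimethoxyphenyl on a carbonyl carbon gives a number 14 percentage points lower from compound 1 to compound 4 (beyond the scatter), so a single change at this position moves the read-out beyond the usual scatter, though only modestly. Among these compounds, the one earlier step, a number 3 percentage points lower from compound 2 to compound 3 (within the scatter), involved hydrogen in place of methoxy on an aromatic carbon and gave no readable change, which makes the group on the carbonyl carbon the only place in this small set where one exchange has shifted the number by more than the scatter. The change swaps a group with 0 hydrogen-bond acceptors for one with 2 and replaces chlorine with oxygen-bearing substituents, but nothing measured here gives a reason for the step.

The compounds shown leave open whether the two methoxy groups act together or one alone accounts for the step, and whether a nitrile or a carboxylic acid on this phenyl ring would carry the number further in the same direction. They also leave open whether the step would hold at any other concentration, since this read-out comes from a single one.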